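A pyridin-2-yl swap in an antiproliferative series

The compounds below may be only part of what the source reports. "The series", "measured", "known", "first", "only" and "open" are said of these compounds alone.

Measured in a functional assay on HeLa cells (Homo sapiens) for antiproliferative activity, read by MTT assay, with a stated time of 72 h; a higher number here means a weaker inhibitor, a lower number a stronger inhibitor:
- compound 1 `Nc1nc(N)c2cc(CSC(=S)N3CCN(C4CCCCC4)CC3)ccc2n1`: 5960 nM
- compound 2 `Nc1nc(N)c2cc(CSC(=S)N3CCN(c4ccccc4Cl)CC3)ccc2n1`: 4050 nM
- compound 3 `Nc1nc(N)c2cc(CSC(=S)N3CCN(c4ccc(F)cc4)CC3)ccc2n1`: 1840 nM

Compound 3 has the lowest number of the three and stands clear of the other two, with a 3.2-fold lower number from compound 1 to compound 3 (0.51 log units; beyond the scatter) and a 2.2-fold lower number from compound 2 to compound 3 (0.34 log units; beyond the scatter) as its modest steps. Compound 4 `Nc1nc(N)c2cc(CSC(=S)N3CCN(c4ccccn4)CC3)ccc2n1` keeps the shared core but carries pyridin-2-yl in place of 4-fluorophenyl on an amine nitrogen in a ring.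

All three measured steps changed this same place. The two that reached compound 3 were modest, and a 1.5-fold lower number from compound 1 to compound 2 (0.17 log units; within the scatter) stayed within the scatter. Within the data shown here, none of the measured compounds has a hetero atom in this aromatic ring, so the evidence is indirect. Since compound 3 (1840 nM) sits at the low end, a modest rise in this assay is expected, though a step within the scatter would be no surprise. The estimate amounts to a 1.5-fold higher number from compound 3 to compound 4 (0.18 log units; within the scatter). For compound 4 the expected value is 2800 nM, with an estimated range from 1200 nM to 6000 nM.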

Compound 4, half-maximal inhibitory concentration: 5090 nM
The estimate for compound 4 lay 1.8-fold (0.26 log units) below the measured number; the measured number falls inside the stated range.
By their numbers in this assay, from the lowest: compound 3; then compounds 2, 4 and 1 (each within the scatter of the next).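

Pyridin-2-yl is the first group here to put a hetero atom into the aromatic ring at this position, and in this assay it gives a 2.8-fold higher number from compound 3 to compound 4 (0.44 log units; beyond the scatter), so the low number of compound 3 does not carry over to this ring. Against the other two groups the change cannot be told apart: a 1.3-fold higher number from compound 2 to compound 4 (0.10 log units; within the scatter) and a 1.2-fold lower number from compound 1 to compound 4 (0.07 log units; within the scatter) both stay within the scatter, which leaves 4-fluorophenyl as the only group of the four that stands clear at this place. Nothing measured here accounts for the step.

4-fluorophenyl and pyridin-2-yl differ both in the fluorine and in the ring nitrogen, so it stays open which of the two goes with the rise. An unsubstituted phenyl group would separate them.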